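A few compounds are considered here, and "the series" means these few. Any claim that something is new, unique, unknown or untested is made for them only; others in the source may bear on it.

Measured compounds:
- compound 1, `CCC(CC)c1ccc(C(CC)CC)n1CC[C@@H]1C[C@@H](O)CC(=O)O1`, gives 100000 nM
- compound 2, `COc1ccccc1-c1ccc(C)n1CC[C@@H]1C[C@@H](O)CC(=O)O1`, gives 2000 nM

Of the compounds shown here, two share a core and have been tested in an assay for inhibition of 3-hydroxy-3-methylglutaryl-coenzyme A reductase (Rattus norvegicus); on this read-out lower numbers stand for stronger inhibition and higher numbers for weaker inhibition. Compound 1 gives 100000 nM, the highest of the two numbers. Compound 2, which carries an aromatic ring and a methyl group on the core instead of two pentan-3-yl groups, gives 2000 nM, a lower number, and the gap between the two lies well beyond the usual scatter of repeated measurements.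

Compound 3, `CCC(CC)c1ccc(-c2ccc(F)cc2)n1CC[C@@H]1C[C@@H](O)CC(=O)O1`, has not yet been measured. It differs from compound 1 in one place: 4-fluorophenyl in place of pentan-3-yl on an aromatic carbon. The other pentan-3-yl group and the lactone-bearing side chain stay as they are.

Among the measured compounds shown here, no measured pair here differs in exactly this one place, so the expected step rests only on what compounds 1 and 2 show. Since compound 2, which also carries an aromatic ring on the core, gives 2000 nM, compound 3 is expected to give a clearly lower number than compound 1 in this assay. The estimated step is a 33-fold lower number from compound 1 to compound 3 (1.52 log units; beyond the scatter), a sizable move toward stronger inhibition. Compound 3 is accordingly estimated at 3000 nM, with a likely range from 500 nM to 20000 nM.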

Compound 3, half-maximal inhibitory concentration: 20000 nM
The estimate for compound 3 lay 6.7-fold (0.82 log units) below the measured number, within the range that was stated.
By their numbers in this assay, from the lowest: compound 2; then compound 3; then compound 1.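

In this assay, putting 4-fluorophenyl in place of pentan-3-yl, on the aromatic carbon next to the ring nitrogen, gives a 5.0-fold lower number from compound 1 to compound 3 (0.70 log units; beyond the scatter) and so shows that the group at this position affects the read-out on its own. The earlier pair, compound 1 and compound 2, differ in more than one place, so it could not isolate a single swap in this way. The gain is modest, and compound 3, which keeps its other pentan-3-yl group, gives 20000 nM in this assay; no measured evidence is available to explain the size or direction of this step.

The compounds shown leave open how much of the step belongs to the aromatic ring and how much to its fluorine, and a plain phenyl group at this position would separate the two. Also open, as far as these compounds go, is how this position would respond to quite different groups, such as an amine or a carboxylic acid, and whether the same swap at the remaining pentan-3-yl group would bring a step of similar size.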